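Where a Larger Group Enters on the Ring Carbon

The compounds below may be only part of what the source reports. "The series", "measured", "known", "first", "only" and "open" are said of these compounds alone.

Compound 1 `COCCOc1cc2ncnc(NC3=CC(=O)C(SC)=CC3=O)c2cc1OC`: 3 h
Compound 2 `COCCOc1cc2ncnc(NC3=CC(=O)C(N(C)c4ccccc4)=CC3=O)c2cc1OC`: 295 h

In an ADME assay for pharmacokinetics, tested at 10 uM, in the presence of a further agent that is not named here (on this read-out higher numbers stand for a longer-lived compound and lower numbers for a shorter-lived compound), compound 1 gives 3 h and compound 2 gives 295 h, the higher of the two numbers. Among the measured compounds shown here, the single measured step, a 98-fold higher number from compound 1 to compound 2 (1.99 log units; beyond the scatter), shows that the group on this ring carbon can move the read-out greatly. Compound 3 `COCCOc1cc2ncnc(NC3=CC(=O)C(Oc4ccc(-n5ccnc5)cc4)=CC3=O)c2cc1OC` differs from compound 2 by 4-(1H-imidazol-1-yl)phenoxy in place of methyl(phenyl)amino on a double-bonded ring carbon. For the measured compounds named here, no measured step sets these two groups against each other, so the direction is open and only the sensitivity of the position is known. Compound 3 is therefore expected at 60 h, within a range from 8 h to 400 h. That amounts to an expected step of a 4.9-fold lower number from compound 2 to compound 3 (0.69 log units; beyond the scatter).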

Compound 3, half-life: < 0.02 h
Compound 3: a limit, no number; the forecaster's own chance of this, stated with the estimate: 10%; middle value at least 3000-fold (3.47 log units) away from the limit.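

The value of compound 3 in this assay is a limit and not a number: the limit of < 0.02 h in this assay, at which 1 of the 3 values shown sits.

Against the two earlier groups, the change gives an at least 14000-fold lower number from compound 2 to compound 3 (4.16 log units; beyond the scatter) and an at least 150-fold lower number from compound 1 to compound 3 (2.17 log units; beyond the scatter). This ring carbon can therefore take the read-out down as well as up, and 4-(1H-imidazol-1-yl)phenoxy gives the lowest result of the three groups shown.

From the compounds shown here alone, whether the drop belongs to the oxygen link or to the imidazole ring stays open. A plain phenoxy group on the same ring carbon would separate the two.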